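The source may hold more compounds than are shown below. What is called first, only, known or untested is meant among the compounds shown, and "the series" means these compounds.

Working notes on the nitrofuran series, cytotoxicity arm.

Among the measured compounds shown here, the three measured members share one core and differ only in the substituent on the aniline nitrogen. Compound 1 `CC(=O)Nc1cccc(-c2csc(NC(=O)c3ccc([N+](=O)[O-])o3)n2)c1` carries an acetyl group there; in an ADME assay on Vero cells (Chlorocebus sabaeus) for cytotoxicity, read by MTT assay, with a stated time of 72 h (a lower number here means a stronger inhibitor, a higher number a weaker inhibitor), compound 1 gives 57600 nM. Compound 2 `O=C(Nc1cccc(-c2csc(NC(=O)c3ccc([N+](=O)[O-])o3)n2)c1)c1ccccc1` carries a benzoyl group; in this assay compound 2 gives 50200 nM. The step of a 1.1-fold lower number from compound 1 to compound 2 (0.06 log units; within the scatter) is therefore flat. Compound 3 `CS(=O)(=O)Nc1cccc(-c2csc(NC(=O)c3ccc([N+](=O)[O-])o3)n2)c1` carries a methylsulfonyl group instead. For compound 3 the assay returns only a limit, < 2820 nM, so compound 3 stands at an edge of the numbers rather than on one; the reading the limit of < 2820 nM in this assay, at which 1 of the 3 values shown sits, marks where that edge lies. The steps of an at least 20-fold lower number from compound 1 to compound 3 (1.31 log units; beyond the scatter) and an at least 17-fold lower number from compound 2 to compound 3 (1.25 log units; beyond the scatter) are both large and run in the same direction, toward a lower number.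

Compound 4 `O=C(Nc1nc(-c2cccc(NS(=O)(=O)Cc3ccccc3)c2)cs1)c1ccc([N+](=O)[O-])o1` is the next member to be measured. It differs from compound 3 by phenyl in place of hydrogen on a saturated chain carbon bound to a sulfonyl sulfur. For the measured compounds named here, no measured step changes the sulfonyl side in this way; the closest guide is the flat step a 1.1-fold lower number from compound 1 to compound 2 (0.06 log units; within the scatter), where a phenyl entering in place of methyl on the carbonyl side moved nothing beyond the scatter. Since compound 3 sits at a limit, only a step toward higher numbers could become visible. Compound 4 is therefore expected to return a value near the edge, estimated at 3000 nM, within 500 nM to 15000 nM, which means an expected step of an at least 1.0-fold higher number from compound 3 to compound 4 (0.02 log units; that floor lies within the scatter).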

Compound 4, half-maximal inhibitory concentration: 59300 nM
For compound 4 the middle estimate is 20-fold (1.30 log units) below the measured one, and the stated range ends below it.
By their numbers in this assay, from the lowest: compounds 2, 1 and 4 (each within the scatter of the next). At a limit, below all of these: compound 3.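

Up to this point the sulfonyl side of the series was known only from compound 3, so a sulfonyl group on the aniline nitrogen could have been read as enough for a low reading in this assay. Phenyl in place of hydrogen on a saturated chain carbon bound to a sulfonyl sulfur removes that reading, giving an at least 21-fold higher number from compound 3 to compound 4 (1.32 log units; beyond the scatter) as a large step, so the sulfonyl group alone does not set the value. The benzylsulfonyl group reads level with both carbonyl groups, with a 1.0-fold higher number from compound 1 to compound 4 (0.01 log units; within the scatter) and a 1.2-fold higher number from compound 2 to compound 4 (0.07 log units; within the scatter) both within the scatter, which leaves compound 3 as the only member apart from the others, and its reading is a limit, not a number: the limit of < 2820 nM in this assay, at which 1 of the 4 values shown sits.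

On these data alone, the true size of every step from compound 3 stays open, since only a limit stands for it. Also open, as far as these compounds go, is whether an ethylsulfonyl group, a longer chain on the sulfonyl sulfur or a phenylsulfonyl group on the same nitrogen would read with compound 3 or with compound 4.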